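Working notes: ethyl in place of hydrogen on the chain

The compounds below may be only part of what the source reports. "The series", "measured", "known", "first", "only" and "open" are said of these compounds alone.

Values in a functional assay on A549 cells (Homo sapiens) for antiproliferative activity, read by MTT assay, with a stated time of 48 h; on this read-out higher numbers stand for weaker inhibition of growth and lower numbers for stronger inhibition of growth
- compound 1 `Cc1ccc(-c2cnc(N(CCCCOc3ccccc3)Cc3ccc(C(=O)NO)cc3)s2)cc1` gives 14200 nM
- compound 2 `CCCCN(Cc1ccc(C(=O)NO)cc1)c1ncc(-c2ccc(C)cc2)s1` gives 4780 nM

Compound 2 holds the lower of the two numbers. Compound 3 `CCCCCCN(Cc1ccc(C(=O)NO)cc1)c1ncc(-c2ccc(C)cc2)s1` differs from compound 2 by ethyl in place of hydrogen on a saturated chain carbon, four bonds along the chain from a nitrogen on an aromatic ring in the form of ethyl in place of hydrogen on a saturated chain carbon, four bonds along the chain from a nitrogen on an aromatic ring. Going by the values given here, the only measured change at that place is phenoxy giving way to hydrogen, with a 3.0-fold lower number from compound 1 to compound 2 (0.47 log units; beyond the scatter) as a modest step. A slightly higher number is therefore expected, probably within the scatter, and a 1.3-fold higher number from compound 2 to compound 3 (0.10 log units; within the scatter) is the expected step. Estimated for compound 3 is 6000 nM with 2500 nM to 14000 nM as its range.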

Compound 3, concentration for 50% growth inhibition: 3710 nM
For compound 3 the middle estimate is 1.6-fold (0.21 log units) above the measured one, and the stated range covers the measured number.
By their numbers in this assay, from the lowest: compounds 3 and 2 (each within the scatter of the next); then compound 1.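

In this assay, ethyl in place of hydrogen on this chain gives no separable change (a 1.3-fold lower number from compound 2 to compound 3 (0.11 log units; within the scatter)), so compound 2 and compound 3 cannot be told apart by this change. Ethyl in place of phenoxy (a 3.8-fold lower number from compound 1 to compound 3 (0.58 log units; beyond the scatter)) gives a second step from compound 1 that lies beyond the scatter, so that separation now rests on two plain alkyl chains. No evidence is at hand on the origin of either step. On these data alone, whether an amine, a carboxylic acid or a longer chain such as octyl at this place would stay with compound 3 remains open.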